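The source may hold more compounds than are shown below. What is called first, only, known or untested is meant among the compounds shown, and "the series" means these compounds.

Compound 3 `Cc1ccc(OCC(=O)N(Cc2cccs2)C2CCCCC2)cc1` gives 40000 nM in an assay on HEK293 cells for agonist activity at transient receptor potential cation channel subfamily M member 8 (Homo sapiens), read by fluorescence and calcium flux, with a stated time of 15 min (a higher number here means that more compound is needed for the effect, a lower number that less compound is needed), the highest of the three numbers in hand. Compound 2 `Cc1ccc(OCC(=O)N(Cc2cccs2)c2ncccn2)cc1` gives 3700 nM in this assay, and compound 1 `CCN(Cc1cccs1)C(=O)C(C)Oc1ccc(C)cc1` gives 889 nM. Within the data shown here, the single one-point step measured so far is an 11-fold higher number from compound 2 to compound 3 (1.03 log units; beyond the scatter). Compound 4 `Cc1ccc(OCC(=O)N(Cc2cccs2)c2ccn(C)n2)cc1` differs from compound 3 by 1-methyl-1H-pyrazol-3-yl in place of cyclohexyl on an amide-type nitrogen. This change bears on that step: a five-membered aromatic ring with two hetero atoms replaces the saturated ring on the amide-type nitrogen, the mirror image of the cyclohexyl-for-pyrimidinyl swap, so a step of comparable size in the opposite direction, toward a lower number, is expected, namely an 11-fold lower number from compound 3 to compound 4 (1.06 log units; beyond the scatter). Compound 4 is therefore estimated at 3500 nM in this assay, with a range of 1000 nM to 12000 nM.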

Compound 4, half-maximal effective concentration: 855 nM
The estimate for compound 4 lay 4.1-fold (0.61 log units) above the measured number; measured number outside the range, below it.
By their numbers in this assay, from the lowest: compounds 4 and 1 (each within the scatter of the next); then compound 2; then compound 3.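

In this assay, the amide-type nitrogen responds strongly to the ring it carries, with a 47-fold lower number from compound 3 to compound 4 (1.67 log units; beyond the scatter) on replacing cyclohexyl with 1-methyl-1H-pyrazol-3-yl. The two aromatic rings are not interchangeable either, as there is a 4.3-fold lower number from compound 2 to compound 4 (0.64 log units; beyond the scatter), so among compounds 2, 3 and 4 the number depends on which aromatic ring is present, not only on the ring being aromatic. Nothing available accounts for either step.

Open, on these data alone, is whether a plain phenyl ring at this place would match compound 4. Also open, as far as these compounds go, is what the methyl on the pyrazole contributes, which the unmethylated pyrazole would show.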